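Uridine triphosphate analogues: aryl to alkyne at the chain end

The source may report more compounds than this note shows. Statements on the series, on what has been measured and on what is new or still open speak of the compounds shown alone.

Within the data shown here, compound 1 `O=c1[nH]/c(=N\OCCCc2ccc(F)cc2)ccn1[C@@H]1O[C@H](COP(=O)(O)OP(=O)(O)OP(=O)(O)O)[C@@H](O)[C@H]1O` gives 1210 nM in a functional assay on 1321-N1 cells for agonist activity at P2Y purinoceptor 6 (Homo sapiens), read by scintillation counting and inositol phosphate accumulation (a higher number here means that more compound is needed for the effect, a lower number that less compound is needed), and stands at the lowest of the two numbers measured so far. Among the measured compounds shown here, its nearest neighbour is compound 2 `O=c1[nH]/c(=N\OCCCc2cccnc2)ccn1[C@@H]1O[C@H](COP(=O)(O)OP(=O)(O)OP(=O)(O)O)[C@@H](O)[C@H]1O`, which gives 2950 nM; the single change there, pyridin-3-yl in place of 4-fluorophenyl on a saturated chain carbon, three bonds along the chain from an oxygen, reads as a 2.4-fold higher number from compound 1 to compound 2 (0.39 log units; beyond the scatter).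

Compound 3 `C#CCCCO/N=c1/ccn([C@@H]2O[C@H](COP(=O)(O)OP(=O)(O)OP(=O)(O)O)[C@@H](O)[C@H]2O)c(=O)[nH]1` is the next member to be measured. Against compound 1 it shows (ethynyl in place of 4-fluorophenyl on a saturated chain carbon, three bonds along the chain from an oxygen). For the measured compounds named here, no measured step covers the loss of the whole aromatic ring for a small unsaturated group, so the only guide is the step from compound 1 to compound 2, where swapping one six-membered aromatic ring for another already cost a modest amount. Taking the ring away altogether is a larger structural move than that swap, and the expectation is therefore a step in the same direction, somewhat beyond the scatter, as a 2.1-fold higher number from compound 1 to compound 3 (0.32 log units; beyond the scatter). For compound 3 the estimated value is 2500 nM, with a range from 700 nM to 9000 nM.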

Compound 3, half-maximal effective concentration: 3000 nM
Compound 3: middle estimate off by 1.2-fold (0.08 log units), on the low side, and the stated range covers the measured number.
By their numbers in this assay, from the lowest: compound 1; then compounds 2 and 3 (each within the scatter of the next).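

In this assay, taking away the whole six-membered aromatic ring of carbon and leaving only ethynyl at this position, on a saturated chain carbon, three bonds along the chain from an oxygen, gives a modest change (a 2.5-fold higher number from compound 1 to compound 3 (0.39 log units; beyond the scatter)), so a measurable response does not depend on an aromatic ring at the chain end. Ethynyl and pyridin-3-yl cannot be told apart at this position (a 1.0-fold higher number from compound 2 to compound 3 (0.01 log units; within the scatter)), so a ring-free group and a ring-bearing group read alike here, while compound 1 remains the only member set apart from the others. No measurement at hand explains why this position responds in this way.

The compounds shown leave open whether the fluorine or the carbon-only aromatic ring sets compound 1 apart, a question that an unsubstituted phenyl at the same position would address. They also leave open how the chain end tolerates an amine or a carboxylic acid, and whether a longer chain carrying the ethynyl group would read differently from the pent-4-yn-1-yl chain of compound 3.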